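Furan-3-yl in place of propyl: expectation for compound 3

The source may report more compounds than this note shows. Statements on the series, on what has been measured and on what is new or still open speak of the compounds shown alone.

compound 1 `O=C(O)c1cccc(CN2CCC(c3cn(Cc4ccoc4)c4ccccc34)CC2)c1` – 560 nM
compound 2 `CCCCn1cc(C2CCN(Cc3ccc(OC)c(C(=O)O)c3)CC2)c2ccccc21` – 475 nM

Both numbers come from an assay on isolated protein for inhibition of histamine H1 receptor (Cavia porcellus); on this read-out lower numbers stand for stronger inhibition and higher numbers for weaker inhibition. Compound 2 stands at the lower of the two, yet compound 1 sits within the scatter of it, so the pair reads as alike. Compound 3 `COc1ccc(CN2CCC(c3cn(Cc4ccoc4)c4ccccc34)CC2)cc1C(=O)O` is compound 2 with furan-3-yl in place of propyl on a saturated chain carbon bound to an aromatic nitrogen. For the measured compounds named here, no measured pair isolates this change; compound 1 carries the same entering group, has no methoxy group, and its number lies within the scatter of compound 2. The step in this assay is therefore expected to be small, in no set direction, a 1.1-fold higher number from compound 2 to compound 3 (0.02 log units; within the scatter). For compound 3 the expected value is 500 nM, between 200 nM and 1300 nM.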

Compound 3, half-maximal inhibitory concentration: 205 nM
For compound 3 the middle estimate is 2.4-fold (0.39 log units) above the measured one, and the stated range covers the measured number.
By their numbers in this assay, from the lowest: compound 3; then compounds 2 and 1 (each within the scatter of the next).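

In this assay, furan-3-yl in place of propyl on a saturated chain carbon bound to an aromatic nitrogen gives a 2.3-fold lower number from compound 2 to compound 3 (0.36 log units; beyond the scatter), so this position responds to the change when the methoxy group is present. Methoxy in place of hydrogen on an aromatic carbon gives a 2.7-fold lower number from compound 1 to compound 3 (0.44 log units; beyond the scatter); compounds 1 and 2 differ in two places and could isolate neither change. Nothing available here accounts for either step.

Going by these compounds, whether the methoxy step holds with butyl on the aromatic nitrogen remains open. So does whether phenyl or thiophen-3-yl would match furan-3-yl.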